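Changing a Sulfur Substituent at the Assay Limit

The source may hold more compounds than are shown below. What is called first, only, known or untested is meant among the compounds shown, and "the series" means these compounds.

In a functional assay on PC-3 cells (Homo sapiens) for inhibition, read by MTT assay, with a stated time of 72 h (a lower number here means a stronger inhibitor, a higher number a weaker inhibitor), compound 1 (`FC(F)(F)c1ccc(CSc2nc(Sc3ncccn3)cc(C(F)(F)F)n2)cc1`) gives > 50000 nM as a limit of the assay. Compound 2 (`FC(F)(F)c1ccc(CSc2nc(Sc3nnnn3-c3ccccc3)cc(C(F)(F)F)n2)cc1`) gives 45300 nM as a measured number. Compound 3 (`Cc1nnc(Sc2cc(C(F)(F)F)nc(SCc3ccc(C(F)(F)F)cc3)n2)s1`) stands only at > 50000 nM as a limit, not a number. Compound 4 (`FC(F)(F)c1ccc(CSc2nc(Sc3ncc(-c4ccncc4)s3)cc(C(F)(F)F)n2)cc1`) carries 5-(pyridin-4-yl)-1,3-thiazol-2-yl in place of 5-methyl-1,3,4-thiadiazol-2-yl on a sulfur. Earlier swaps on this sulfur gave a step that the two limits leave unreadable from compound 1 to compound 3 and an at least 1.1-fold lower number from compound 1 to compound 2 (0.04 log units; that floor lies within the scatter) and an at least 1.1-fold higher number from compound 2 to compound 3 (0.04 log units; that floor lies within the scatter) with both readable floors inside the scatter. With the limit of > 50000 nM in this assay, at which 2 of the 3 values shown sit, in view, no step beyond the scatter is expected in this assay here. The estimated change is an at least 1.2-fold lower number from compound 3 to compound 4 (0.09 log units; that floor lies within the scatter) and nothing larger is expected. Compound 4 is estimated at 40000 nM with an expected range from 15000 nM to 50000 nM in this measurement.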

Compound 4, half-maximal inhibitory concentration: 7350 nM
Estimate against measurement, compound 4: 5.4-fold (0.74 log units) above; measured number below the stated range.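

In this assay the group on this sulfur now moves the number beyond the scatter, which no earlier swap had shown. 5-(pyridin-4-yl)-1,3-thiazol-2-yl gives an at least 6.8-fold lower number from compound 3 to compound 4 (0.83 log units; beyond the scatter) and an at least 6.8-fold lower number from compound 1 to compound 4 (0.83 log units; beyond the scatter) as floors set by limits, and a 6.2-fold lower number from compound 2 to compound 4 (0.79 log units; beyond the scatter) as a step between two measured numbers. The compounds shown leave open which part of the entering group carries this step, and whether an amine or a carboxylic acid in place of the pyridin-4-yl part would keep it.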